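From benzyl to pentafluoroethyl, with one number to go on

The compounds below may be only part of what the source reports. "The series", "measured", "known", "first", "only" and "open" are said of these compounds alone.

Measured so far in an in vitro ADME assay on microsomes from liver (Homo sapiens) for metabolic stability; on this read-out lower numbers stand for slow clearance and higher numbers for fast clearance:
- compound 1 `Fc1ccccc1Cc1nc(-c2nc(Cc3ccccc3)n[nH]2)n2ccccc12` gives "not determined" (no result reported)
- compound 2 `Fc1ccccc1Cc1nc(-c2nc(C(F)(F)F)n[nH]2)c2ccccn12` gives 20 mL.min-1.g-1
- compound 3 `FC(F)(F)c1n[nH]c(-c2nc(Cc3cncnc3)c3ccccn23)n1` gives < 7 mL.min-1.g-1

Compound 1 stands at "not determined" (no result reported) in this assay and so offers no number to start from. Compound 3 gives < 7 mL.min-1.g-1 as its reading, which is a limit of the assay and not a number. Going by the values given here, the series therefore holds the limit of < 7 mL.min-1.g-1 in this assay, at which 1 of the 3 values shown sits, and only one plain number. Compound 2 supplies that number, 20 mL.min-1.g-1, and it is the only firm reference.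

Compound 4 `Fc1ccccc1Cc1nc(-c2nc(C(F)(F)C(F)(F)F)n[nH]2)n2ccccc12` is still to be measured. The change is 1,1,2,2,2-pentafluoroethyl in place of benzyl on an aromatic carbon and it puts 1,1,2,2,2-pentafluoroethyl in place of benzyl on an aromatic carbon of a five-membered aromatic ring with 3 nitrogen.

Among the compounds with values here, with no number for compound 1, no step can be sized from it. Compound 2 carries trifluoromethyl on that same kind of ring, and with its 20 mL.min-1.g-1 as a guide, compound 4 is expected to land close to that reading, with no shift beyond the usual scatter. Compound 3 carries trifluoromethyl as well, so the guide is a loose one. For compound 4 the estimated clearance is 25 mL.min-1.g-1 in this assay with an expected range from 10 mL.min-1.g-1 to 60 mL.min-1.g-1 around that figure.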

Compound 4, intrinsic clearance in microsomes: 92 mL.min-1.g-1
Beside the measured number, compound 4's estimate is 3.7-fold (0.57 log units) below it; the measured number lies above the stated range.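

In this assay, going by these compounds alone, compound 4 gives 92 mL.min-1.g-1, but compound 1 offers no number, so no step from compound 1 to compound 4 can be read. The compounds shown leave open how benzyl and 1,1,2,2,2-pentafluoroethyl compare on the shared core. Nothing shown here bears on the cause of the reading of compound 4.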